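Imidazole to carboxamide-bearing pyrazole: lipophilicity of compound 4

The source may report more compounds than this note shows. Statements on the series, on what has been measured and on what is new or still open speak of the compounds shown alone.

Compound 1: `Cc1nccn1-c1cnc(NCc2c(F)ccc3c2CCO3)c2cn[nH]c(=O)c12` — 2.1
Compound 2: `O=C1c2ccccc2CN1c1cnc(NCc2c(F)ccc3c2CCO3)n2cnnc12` — 2.7
Compound 3: `Fc1ccc2c(c1CNc1ncc(Oc3ccccc3)c3nncn13)CCO2` — 3.5

In a physicochemical assay for lipophilicity, using the shake flask method, in phosphate buffer, measured as octanol-water partition, with a stated time of 30 min, at pH 7.4 (on this read-out higher numbers stand for higher lipophilicity and lower numbers for lower lipophilicity), compound 1 gives the lowest of the three numbers, with compound 2 a step beyond the scatter above it and compound 3 further above still. For the measured compounds named here, the only measured step that changes a single place, a number 0.80 log units higher from compound 2 to compound 3 (beyond the scatter), sits on a different core and exchanges unrelated groups, so it does not bear on the present change. Compound 4, `CNC(=O)c1cc(-c2cnc(NCc3c(F)ccc4c3CCO4)c3cn[nH]c(=O)c23)n(C)n1`, differs from compound 1 by 1-methyl-3-(methylcarbamoyl)-1H-pyrazol-5-yl in place of 2-methyl-1H-imidazol-1-yl on an aromatic carbon. Without a matching measured step, the change is expected to give a number 0.10 log units lower from compound 1 to compound 4 (within the scatter), not beyond the scatter. Compound 4 is therefore estimated at 2, within 1.4 to 2.6.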

Compound 4, distribution coefficient: 2.1
Compound 4: the middle estimate sits 0.10 log units below what was measured, within the range that was stated.
By their numbers in this assay, from the lowest: compounds 1 and 4 (each within the scatter of the next); then compound 2; then compound 3.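

In this assay, 1-methyl-3-(methylcarbamoyl)-1H-pyrazol-5-yl in place of 2-methyl-1H-imidazol-1-yl gives no change at the digits printed from compound 1 to compound 4 (within the scatter) on this aromatic carbon of the shared core. For the compounds shown here, this is the first reading at this position, and it shows that the entering group, with more heavy atoms and a hydrogen-bond donor that the leaving group lacks, moves the read-out by nothing beyond the scatter. No measured evidence accounts for this result.

On these data alone, it remains open whether this holds for other groups here, such as a primary amine or a carboxylic acid. A longer alkyl chain on the amide nitrogen is equally untested by the compounds shown.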